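The source may report more compounds than this note shows. Statements on the series, on what has been measured and on what is new or still open speak of the compounds shown alone.

In an ADME assay on J774 cells (Mus musculus) for antiproliferative activity, with a stated time of 72 h (on this read-out lower numbers stand for an effect already at smaller amounts and higher numbers for an effect only at larger amounts of compound), compound 1 `CCCCc1cc2c(=O)c(-c3ccccc3)c(C)[nH]c2cc1OCCOc1ccccc1` gives 23000 nM and compound 2 `CCCCc1cc2c(=O)c(-c3ccc(Oc4ccc(OC(F)(F)F)cc4)cc3C)c(C)[nH]c2cc1OCCOc1ccccc1` gives 16000 nM. Within the data shown here, these two values lie within the usual scatter of each other, so compound 2 stands level with the only other measured compound. Compound 3 `CCCCc1cc2c(=O)c(-c3ccc(C)cc3C)c(C)[nH]c2cc1OCCOc1ccccc1` differs from compound 2 at one place, with methyl in place of 4-(trifluoromethoxy)phenoxy on an aromatic carbon. Among the measured compounds shown here, no measured pair isolates this change, so no step beyond the scatter is expected in this assay. The expected change is small, an estimated 1.3-fold higher number from compound 2 to compound 3 (0.10 log units; within the scatter). The estimate for compound 3 is 20000 nM, with an expected range of 10000 nM to 40000 nM.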

Compound 3, half-maximal effective concentration: 22000 nM
The estimate for compound 3 lay 1.1-fold (0.04 log units) below the measured number, within the range that was stated.
By their numbers in this assay, from the lowest: compounds 2, 3 and 1 (each within the scatter of the next).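

In this assay, methyl in place of 4-(trifluoromethoxy)phenoxy on an aromatic carbon (a 1.4-fold higher number from compound 2 to compound 3 (0.14 log units; within the scatter)) shows that this place takes a group of 1 heavy atom or one of 12 heavy atoms with no step beyond the scatter. The 2,4-dimethylphenyl in place of phenyl (a 1.0-fold lower number from compound 1 to compound 3 (0.02 log units; within the scatter)) likewise leaves the number within the scatter, so all three compounds stand level. Nothing measured on these compounds bears on why the numbers stay level. On these data alone, whether an amine or a carboxylic acid at this place would move the number remains open. So does the effect of a shorter chain in place of the butyl group on the core.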